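Moving the nitrile from compound 2 to compound 3

The source may hold more compounds than are shown below. What is called first, only, known or untested is meant among the compounds shown, and "the series" means these compounds.

Measured so far in a functional assay on MDA-MB-231 cells (Homo sapiens) for antiproliferative activity, read by MTT assay, with a stated time of 72 h; on this read-out higher numbers stand for weaker inhibition and lower numbers for stronger inhibition 
- compound 1 `COc1ccc(-c2cccc(NC(=O)CCc3cccc4c3B(O)OC4)c2)cc1` gives 88 nM 
- compound 2 `N#Cc1cccc(-c2cccc(NC(=O)CCc3cccc4c3B(O)OC4)c2)c1` gives 110 nM 

Compound 2 at 110 nM lies within the scatter of compound 1 at 88 nM and the two cannot be ranked. Compound 3 `N#Cc1ccc(-c2cccc(NC(=O)CCc3cccc4c3B(O)OC4)c2)cc1` differs from compound 2 by 4-cyanophenyl in place of 3-cyanophenyl on an aromatic carbon with 4-cyanophenyl in place of 3-cyanophenyl on an aromatic carbon. Going by the values given here, the only measured step, a 1.3-fold higher number from compound 1 to compound 2 (0.10 log units; within the scatter) in this assay and it involves a different swap, so it bears on this change only indirectly. No step beyond the scatter is expected, and the estimated step is a 1.1-fold lower number from compound 2 to compound 3 (0.04 log units; within the scatter) for now. In this assay the expected value for compound 3 is 100 nM within an estimated range of 40 nM to 250 nM for now.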

Compound 3, half-maximal inhibitory concentration: 380 nM
The estimate for compound 3 lay 3.8-fold (0.58 log units) below the measured number, and the stated range ends below it.
By their numbers in this assay, from the lowest: compounds 1 and 2 (each within the scatter of the next); then compound 3.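

Where the nitrile sits matters here: in this assay, 4-cyanophenyl in place of 3-cyanophenyl gives a 3.5-fold higher number from compound 2 to compound 3 (0.54 log units; beyond the scatter), although the two compounds hold the same atoms. Cyano in place of methoxy gives a 4.3-fold higher number from compound 1 to compound 3 (0.64 log units; beyond the scatter), so the nitrile now separates from the methoxy, which the earlier pair could not show. Nothing at hand explains the shift.

From the compounds shown here alone, it remains open whether the higher number is tied to the nitrile or would recur with an amine or a carboxylic acid in the same place.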